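A few compounds are considered here, and "the series" means these few. Any claim that something is new, unique, unknown or untested is made for them only; others in the source may bear on it.

Measured in a functional assay on FaDu cells (Homo sapiens) for cytotoxicity, read by MTT assay, with a stated time of 72 h; on this read-out lower numbers stand for higher toxicity in this test and higher numbers for lower toxicity in this test:
Compound 1 `COc1ccc(NC(=O)C(=O)c2cn(C(C)(C)COCC(=O)O)c3ccccc23)cn1`: > 10000 nM (a limit)
Compound 2 `COc1ccc(NC(=O)C(=O)c2cn(CC(C)(C)OC)c3ccccc23)cn1`: > 10000 nM (a limit)
Compound 3 `CCCCn1cc(C(=O)C(=O)Nc2ccc(OC)nc2)c2ccccc21`: 18 nM

Among the measured compounds shown here, compound 3 gives the only true number in this set, 18 nM. The other two results are limits of the assay, and the series shows (the limit of > 10000 nM in this assay, at which 2 of the 3 values shown sit).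

Compound 4 `COCC(C)(C)n1cc(C(=O)C(=O)Nc2ccc(OC)nc2)c2ccccc21` has not yet been measured. It keeps the core of compound 3 but carries a different group on the aromatic nitrogen: 1-(methoxymethyl)-1-methylethyl in place of butyl on an aromatic nitrogen.

For the measured compounds named here, two measured steps bear on this change, an at least 550-fold lower number from compound 1 to compound 3 (2.74 log units; beyond the scatter) and an at least 550-fold lower number from compound 2 to compound 3 (2.74 log units; beyond the scatter). Both are large, and both end at the butyl chain of compound 3, reached from a larger group containing oxygen. A third, a step that the two limits leave unreadable from compound 1 to compound 2, gives no size. Compound 4 reverses the direction of those two steps by giving up butyl for a larger group containing oxygen, so a large rise in this assay is expected, meaning much lower toxicity. Going by the values given here, no compound with this exact group has been tested, so the size remains uncertain, and a result reported only as a limit is quite likely.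

The expected change is a 440-fold higher number from compound 3 to compound 4 (2.65 log units; beyond the scatter).

For compound 4 the estimated value is 8000 nM, with an expected range from 800 nM to 30000 nM.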

Compound 4, concentration lethal to 50% of the cells: 137 nM
Compound 4: middle estimate off by 58-fold (1.77 log units), on the high side; the whole stated range lies above it.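

In this assay, an oxygen-bearing group on the aromatic nitrogen does not by itself bring the loss seen earlier, since the 1-(methoxymethyl)-1-methylethyl group costs only a modest amount, a 7.6-fold higher number from compound 3 to compound 4 (0.88 log units; beyond the scatter). The arrangement of that group matters, as 1-(methoxymethyl)-1-methylethyl and 2-methoxy-2-methylpropyl give very different results, an at least 72-fold lower number from compound 2 to compound 4 (1.86 log units; beyond the scatter), and the carboxy group at the end of the chain also counts heavily, an at least 72-fold lower number from compound 1 to compound 4 (1.86 log units; beyond the scatter). Both of these large steps start from a limit of the assay, so their true sizes stay unknown and they give only a floor: the limit of > 10000 nM in this assay, at which 2 of the 4 values shown sit.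

The compounds shown leave open whether the modest rise with compound 4 comes from the branching on the carbon bound to the aromatic nitrogen or from the methoxy end, a question that a plain tert-butyl group or a longer unbranched chain ending in methoxy would address. They also leave open whether an amine or a hydroxyl in place of the carboxy group would keep the low number of compound 4 or push it back towards the limit.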